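Trading an indole for a cyanophenyl on the shared core

The source may hold more compounds than are shown below. What is called first, only, known or untested is meant among the compounds shown, and "the series" means these compounds.

Measured so far:
Compound 1, `COc1cc(-c2ccnc3cc(-c4ccc5cc[nH]c5c4)nn23)cc(OC)c1OC`: 187 nM
Compound 2, `COc1cc(-c2ccnc3cc(-c4cn(C(=O)OC(C)(C)C)c5ccccc45)nn23)cc(OC)c1OC`: 5720 nM

Both compounds were tested in a functional assay on HCT-116 cells (Homo sapiens) for inhibition, read by CCK-8 assay, with a stated time of 48 h; on this read-out lower numbers stand for stronger inhibition and higher numbers for weaker inhibition. Compound 1 gives 187 nM, the lowest number of the two. Compound 2 gives 5720 nM, and the gap between the two values lies beyond the usual scatter of repeated measurements, so compound 1 is the stronger inhibitor of the pair. Among the measured compounds shown here, the two differ in more than one place, so no single step connects them.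

Compound 3, `COc1cc(-c2ccnc3cc(-c4cccc(C#N)c4)nn23)cc(OC)c1OC`, has not yet been measured. It differs from compound 1 in one place: 3-cyanophenyl in place of 1H-indol-6-yl on an aromatic carbon. The group that leaves carries a hydrogen-bond donor; the group that enters carries a hydrogen-bond acceptor and no donor. For the measured compounds named here, no measured pair shows what such a swap does on this core. On the two numbers shown, a moderate loss of potency seems the more likely outcome, and the step of a 3.7-fold higher number from compound 1 to compound 3 (0.57 log units; beyond the scatter) is expected to point toward a higher number. Compound 3 is therefore estimated at 700 nM, with a range from 200 nM to 3000 nM.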

Compound 3, half-maximal inhibitory concentration: > 10000 nM
Compound 3 ended at the assay's limit; the forecaster's own chance of this, stated with the estimate: 5%; at least 14-fold (1.15 log units) between middle value and limit.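

In this assay, putting 3-cyanophenyl in place of 1H-indol-6-yl on this aromatic carbon gives an at least 53-fold higher number from compound 1 to compound 3 (1.72 log units; beyond the scatter), so a large loss of activity is now on record for a single change at this place on the shared core. Compound 3 gives > 10000 nM, which is a limit of the assay and not a number. The step can therefore be read only as a minimum, and its true size remains unknown because the value of compound 3 sits at that limit: the limit of > 10000 nM in this assay, at which 1 of the 3 values shown sits.

This one swap changes several things together: a fused five-membered ring goes, a hydrogen-bond donor goes, and a nitrile comes in, so the compounds shown cannot say which of these matters for the result. Also open, on these data alone, is whether a phenyl ring carrying an amine or a hydroxyl group instead of the nitrile, or a plain phenyl ring with no nitrile at all, would stay closer to compound 1 at 187 nM or fall as far as compound 3.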